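A few compounds are considered here, and "the series" means these few. Any claim that something is new, unique, unknown or untested is made for them only; others in the source may bear on it.

Three related compounds have been measured in an ADME assay on HEK293 cells (Homo sapiens) for antiproliferative activity, read by MTT assay; on this read-out higher numbers stand for weaker inhibition and lower numbers for stronger inhibition. Compound 3 (`CNC(=O)c1oc2nc(-c3cccs3)cc(C(F)(F)F)c2c1N`) gives 75000 nM, compound 1 (`CCNC(=O)c1oc2nc(-c3ccccc3)cc(C(F)(F)F)c2c1N`) gives 70000 nM, and compound 2 (`Nc1c(C(=O)N/N=C/c2ccc(Cl)cc2)oc2nc(-c3cccs3)cc(C(F)(F)F)c12`) gives 83000 nM. These numbers lie within the scatter of one another, so compound 3 sits in a tight cluster with no real ranking inside it.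

Compound 4 (`CCNC(=O)c1oc2nc(-c3cccs3)cc(C(F)(F)F)c2c1N`) differs from compound 3 by a single small change: methyl in place of hydrogen on a saturated chain carbon bound to an amide-type nitrogen. This is methyl in place of hydrogen on a saturated chain carbon bound to an amide-type nitrogen, which turns methylcarbamoyl into ethylcarbamoyl.

Going by the values given here, the one measured step on this amide-type nitrogen, a 1.1-fold lower number from compound 2 to compound 3 (0.04 log units; within the scatter), swaps a much larger group and still stays within the scatter. Compound 1 already carries ethylcarbamoyl, on a core that differs elsewhere, and its 70000 nM falls in the same cluster.

No change beyond the scatter is therefore expected in this assay, and the estimated step is no change at the digits printed from compound 3 to compound 4 (within the scatter). For compound 4 the expected value is 75000 nM, with an estimated range from 45000 nM to 120000 nM.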

Compound 4, half-maximal inhibitory concentration: 62000 nM
For compound 4 the middle estimate is 1.2-fold (0.08 log units) above the measured one, within the range that was stated.
By their numbers in this assay, from the lowest: compounds 4, 1, 3 and 2 (each within the scatter of the next).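

In this assay, going by these compounds alone, methyl in place of hydrogen on a saturated chain carbon bound to an amide-type nitrogen gives a 1.2-fold lower number from compound 3 to compound 4 (0.08 log units; within the scatter) and so separates ethylcarbamoyl from methylcarbamoyl by no real margin on the same core, a direct comparison that the earlier compounds did not offer. The wider comparisons agree: the group on that nitrogen changes in a 1.3-fold lower number from compound 2 to compound 4 (0.13 log units; within the scatter) and thiophen-2-yl replaces phenyl on an aromatic carbon in a 1.1-fold lower number from compound 1 to compound 4 (0.05 log units; within the scatter) with neither step leaving the scatter. No measurement shown offers an explanation for this.

All four compounds therefore remain one unranked cluster, and nothing yet shows a change that moves this read-out. As far as these compounds go, whether a longer chain, an amine or a carboxylic acid on this amide-type nitrogen would do so remains open.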